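A Nitro Group Enters Where a Methyl Stood

The source may hold more compounds than are shown below. What is called first, only, known or untested is meant among the compounds shown, and "the series" means these compounds.

Compound 2 `CC(=O)N1N=C(c2ccc(F)cc2)CC1c1cn(-c2ccccc2)nc1-c1ccc(C)cc1` stands highest of the two compounds measured in a functional assay on the whole organism (Tail) with Rattus norvegicus as the target, in the tail flick test, with a stated time of 60 min, at a dose of 25 mg/kg by the oral route (a lower number here means less inhibition, a higher number more inhibition at the dose given (going by the name of the read-out)), where compound 2 gives 110%. Among the measured compounds shown here, its only neighbour, compound 1 `CC(=O)N1N=C(c2ccc(F)cc2)CC1c1cn(-c2ccccc2)nc1-c1ccc(Br)cc1`, gives 71% in this assay, and the step of a number 39 percentage points higher from compound 1 to compound 2 (beyond the scatter) lies beyond the scatter. Compound 3 `CC(=O)N1N=C(c2ccc(F)cc2)CC1c1cn(-c2ccccc2)nc1-c1cccc([N+](=O)[O-])c1` differs from compound 2 in one place: 3-nitrophenyl in place of 4-methylphenyl on an aromatic carbon. For the measured compounds named here, no measured step tests this exchange, so the step from compound 1 to compound 2 only shows how far a change at this position can move the read-out. Compound 3 is therefore expected to drop, a number 25 percentage points lower from compound 2 to compound 3 (beyond the scatter), to an estimated 85%, within 55% to 115%.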

Compound 3, a percentage reported as inhibition, in the whole organism at one dose (the size of the read-out at that dose, not a potency): 109%
The estimate for compound 3 lay 24 percentage points below the measured number; measured number inside the range.
By their numbers in this assay, from the lowest: compound 1; then compounds 3 and 2 (each within the scatter of the next).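

In this assay the exchange gives a number 1 percentage points lower from compound 2 to compound 3 (within the scatter) and so stays within the scatter, which shows that this aromatic carbon can carry 3-nitrophenyl, with its hydrogen-bond acceptors, as readily as 4-methylphenyl. Among the compounds shown here, the other comparison, a number 38 percentage points higher from compound 1 to compound 3 (beyond the scatter) and beyond the scatter, leaves 4-bromophenyl as the one group of the three set apart here. Nothing available explains this behaviour.

From the compounds shown here alone, whether a phenyl ring carrying an amine or a carboxylic acid would stay level with compound 2 and compound 3 or fall towards compound 1 remains open.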